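The compounds below may be only part of what the source reports. "The series", "measured", "known", "first", "only" and "open" are said of these compounds alone.

In a functional assay on MGC-803 cells (Homo sapiens) for cytotoxicity, read by MTT assay, with a stated time of 48 h (on this read-out lower numbers stand for stronger inhibition and higher numbers for weaker inhibition), compound 2 `CCC(=O)N1N=C(C)CC1c1cc(Br)ccc1O` stands at 50300 nM and lies within the scatter of compound 1 `CC1=NN(C(=O)c2ccc(C)cc2)C(c2ccccc2O)C1` at 26300 nM but beyond it from compound 3 `CC1=NN(C(=O)c2ccc(C)cc2)C(c2cc(Br)ccc2O)C1` at 21000 nM on the lower side. Within the data shown here, compound 4 `CC1=NN(C(=O)COc2ccc(Cl)cc2)C(c2cc(Br)ccc2O)C1` keeps the core and the bromo of compound 2 and differs by 4-chlorophenoxy in place of methyl on a saturated chain carbon bound to a carbonyl carbon as its one structural change. The closest measured evidence is a 2.4-fold lower number from compound 2 to compound 3 (0.38 log units; beyond the scatter) for a change that also replaces ethyl on a carbonyl carbon, there with 4-methylphenyl. The bromo step a 1.3-fold lower number from compound 1 to compound 3 (0.10 log units; within the scatter) stays within the scatter and offers no guide to this change. Among the measured compounds shown here, no measured compound carries 4-chlorophenoxy, so its contribution cannot be read directly. A lower number of similar modest size is therefore expected, and the estimated move is a 2.5-fold lower number from compound 2 to compound 4 (0.40 log units; beyond the scatter) with wide uncertainty. For compound 4 the estimate is 20000 nM as an expected value (range 7000 nM to 55000 nM).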

Compound 4, half-maximal inhibitory concentration: 23600 nM
For compound 4 the middle estimate is 1.2-fold (0.07 log units) below the measured one; measured number inside the range.
By their numbers in this assay, from the lowest: compounds 3, 4, 1 and 2 (each within the scatter of the next, the first and the last beyond it).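

On a saturated chain carbon bound to a carbonyl carbon, 4-chlorophenoxy in place of methyl gives a 2.1-fold lower number from compound 2 to compound 4 (0.33 log units; beyond the scatter) in this assay, so this position accepts a much larger group bearing an aromatic ring without any loss of inhibition, a modest gain being the result. Compound 3 at 21000 nM and compound 4 at 23600 nM lie within the scatter of each other, so two different groups reached through the carbonyl carbon end up at the same level in this series. No measurement shown here accounts for the step.

On these data alone, whether the step depends on the chlorine, the oxygen or the aromatic ring remains open. Phenoxy without chlorine, or an amine or a carboxylic acid on the same carbon, would help separate these parts.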